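Methoxymethyl in Place of Difluoromethoxy on a Shared Core

This account rests on a few compounds, and the source may have more. Where it says the series, first, only, none or still open, it means among the compounds named here.

Of the compounds shown here, three have been measured in an in vitro ADME assay on microsomes from liver (Homo sapiens) for metabolic stability; a lower number here means slower removal, a higher number faster removal of the compound. Compound 1, `FC(F)Oc1ccccc1C1Cc2nccn2C1`, gives 22 mL.min-1.g-1 in this assay. Compound 2, `COc1ccc(C2CCc3nc[nH]c3C2)cc1`, gives 16 mL.min-1.g-1, and compound 3, `Clc1ccccc1C1CCc2nc[nH]c2C1`, gives 10 mL.min-1.g-1. Among these three numbers compound 1 stands highest; its distance to compound 2 lies within the scatter of repeated measurements, while its distance to compound 3 lies beyond it. No two of the measured compounds differ in a single place, so no isolated step can be read from them.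

Compound 4, `COCc1ccccc1C1Cc2nccn2C1`, has not yet been measured. It differs from compound 1 in one place: methoxymethyl in place of difluoromethoxy on an aromatic carbon. For the measured compounds named here, nothing among the measured compounds shows what this particular exchange does in this assay, so the expectation rests on compound 1 alone. The step from compound 1 to compound 4 is expected to be small, most likely within the scatter, with no strong reason to favour either direction: a 1.1-fold lower number from compound 1 to compound 4 (0.04 log units; within the scatter). Compound 4 is therefore expected to give about 20 mL.min-1.g-1 in this assay, with a range from 10 mL.min-1.g-1 to 40 mL.min-1.g-1.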

Compound 4, intrinsic clearance in microsomes: < 7 mL.min-1.g-1
Compound 4 ended at the assay's limit (the forecaster's own chance of this, stated with the estimate: 5%); middle value at least 2.8-fold (0.45 log units) from the limit.
By their numbers in this assay, from the lowest: compounds 3, 2 and 1 (each within the scatter of the next, the first and the last beyond it). At a limit, below all of these: compound 4.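

For the compounds shown here, the exchange of difluoromethoxy for methoxymethyl on an aromatic carbon, ortho to a group of 8 heavy atoms, gives the first single-place comparison in this assay, and the change is not a neutral one: it produces an at least 3.1-fold lower number from compound 1 to compound 4 (0.49 log units; beyond the scatter). The number at this position therefore depends on which of the two groups sits there, although neither group has a ring or a net charge and the two match in their counts of hydrogen-bond donors and acceptors. The full size of the step stays unknown, and only its lower bound can be read: the limit of < 7 mL.min-1.g-1 in this assay, at which 1 of the 4 values shown sits.

The compounds shown cannot tell which part of the exchange carries the step, since the fluorine atoms leave and the carbon and oxygen arrangement changes in the same move, and they give no cause for it. As far as these compounds go, it remains open whether a hydroxymethyl group or an ethyl chain at this place would also bring the number down in this assay, and whether the same exchange would have a comparable effect on the core of compound 2 or compound 3.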